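The source may report more compounds than this note shows. Statements on the series, on what has been measured and on what is new or still open speak of the compounds shown alone.

Compound 1 `CC1=C(/C=C/C(=O)/C=C/c2ccc(Cl)cc2)C(C)(C)CCC1` gives 52300 nM in a functional assay on IMR-32 cells (Homo sapiens) for cytotoxicity, read by sulforhodamine B assay, with a stated time of 48 h; a lower number here means a stronger inhibitor, a higher number a weaker inhibitor. Compound 2 `CC1=C(/C=C/C(=O)/C=C/c2ccc(C)cc2)C(C)(C)CCC1` gives 19200 nM. Compound 3 `CC1=C(/C=C/C(=O)/C=C/c2ccccc2Br)C(C)(C)CCC1` gives 16300 nM.

On these numbers compound 3 has the lowest value of the three, though the gap to compound 2 is small: a 1.2-fold lower number from compound 2 to compound 3 (0.07 log units; within the scatter), so the two cannot be ranked. The gap to compound 1 is clearer: a 3.2-fold lower number from compound 1 to compound 3 (0.51 log units; beyond the scatter).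

Compound 4 `CC1=C(/C=C/C(=O)/C=C/c2cccnc2)C(C)(C)CCC1` differs from compound 3 in one place: pyridin-3-yl in place of 2-bromophenyl on a double-bonded chain carbon bound to a double-bonded chain carbon. Going by the values given here, none of the measured steps swaps the carbon-only ring for a ring with a hetero atom; all three move between substituted phenyls, and they were modest at most: a 2.7-fold lower number from compound 1 to compound 2 (0.44 log units; beyond the scatter), a 3.2-fold lower number from compound 1 to compound 3 (0.51 log units; beyond the scatter), a 1.2-fold lower number from compound 2 to compound 3 (0.07 log units; within the scatter). With so little movement across the measured series, compound 4 is expected to land near compound 3, perhaps slightly higher, with the step of a 1.5-fold higher number from compound 3 to compound 4 (0.19 log units; within the scatter) estimated to stay close to the scatter. The estimate for compound 4 in this assay is 25000 nM, with a range from 8000 nM to 80000 nM.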

Compound 4, half-maximal inhibitory concentration: 25300 nM
Compound 4: middle estimate off by 1.0-fold (0.01 log units), on the low side; measured number inside the range.
By their numbers in this assay, from the lowest: compounds 3, 2 and 4 (each within the scatter of the next); then compound 1.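

With compound 4, a ring with a hetero atom stands at this place on the chain, and in this assay pyridin-3-yl gives a 1.6-fold higher number from compound 3 to compound 4 (0.19 log units; within the scatter) and a 1.3-fold higher number from compound 2 to compound 4 (0.12 log units; within the scatter) so the nitrogen-bearing ring cannot be told apart from the 2-bromophenyl or 4-methylphenyl rings. Going by these compounds alone, the only clear step is a 2.1-fold lower number from compound 1 to compound 4 (0.32 log units; beyond the scatter) which leaves compound 1 with the 4-chlorophenyl ring apart from the other three compounds, while those three cannot be ranked among themselves. Nothing measured here explains why these numbers fall as they do.

The compounds shown leave open whether pyridin-4-yl, with the ring nitrogen elsewhere, would behave like pyridin-3-yl. They also leave open whether a phenyl ring carrying an amine or a carboxylic acid would stay with compounds 2, 3 and 4 or move away from them.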